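A few compounds are considered here, and "the series" means these few. Any claim that something is new, unique, unknown or untested is made for them only; others in the source may bear on it.

Compound 2, `Fc1cccc(-c2nc(Nc3ccc(Cl)cc3)c3cc(F)ccc3n2)c1`, is one of three close relatives examined for cytotoxicity in a functional assay on MCF7 cells (Homo sapiens) for cytotoxicity, read by MTT assay, with a stated time of 48 h; a higher number here means a weaker inhibitor, a lower number a stronger inhibitor. In this assay compound 2 gives > 50000 nM, which is a limit of the assay rather than a number. Compound 1, `COc1ccc(Nc2nc(-c3cccc(F)c3)nc3ccc(F)cc23)cc1`, gives 48400 nM in this assay. Compound 3, `Fc1cccc(-c2nc(Nc3cccc(Cl)c3)c3cc(F)ccc3n2)c1`, also returns a limit in this assay, at > 50000 nM. The step of an at least 1.0-fold higher number from compound 1 to compound 2 (0.01 log units; that floor lies within the scatter) and the step of an at least 1.0-fold higher number from compound 1 to compound 3 (0.01 log units; that floor lies within the scatter) therefore read only as floors, and the step that the two limits leave unreadable from compound 2 to compound 3 cannot be read at all, since the limit of > 50000 nM in this assay, at which 2 of the 3 values shown sit, holds two of the three values. Compound 4, `Nc1ccc(Nc2nc(-c3cccc(F)c3)nc3ccc(F)cc23)cc1`, differs from compound 2 by a single substitution: amino in place of chloro on an aromatic carbon. For the measured compounds named here, no measured step involves an amino group at this place, so the measured steps bear on this change only by showing that every compound here is weak. Compound 4 is expected to stay in that region, with an estimated value of 50000 nM in this assay, between 15000 nM and 160000 nM. The expected step is a number no higher from compound 2 to compound 4 (the limit leaves the size open), though a further limit is the more likely outcome.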

Compound 4, half-maximal inhibitory concentration: > 50000 nM
Compound 4 gave a limit, no number (the forecaster's own chance of this, stated with the estimate: 60%); the middle value sits exactly at the limit.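

Amino on this aromatic carbon, para to a large group, brings no readable cytotoxicity in this assay: compound 4 returns > 50000 nM, which is a limit of the assay and not a number. The step of an at least 1.0-fold higher number from compound 1 to compound 4 (0.01 log units; that floor lies within the scatter) is only a floor, so amino in place of methoxy shows no readable change, and the steps from compound 2 and from compound 3 to compound 4 cannot be read. Amino enters with a hydrogen-bond donor where chloro had none, yet compound 4 joins the two chloro compounds at the same ceiling, so the series now rests mostly on one limit: the limit of > 50000 nM in this assay, at which 3 of the 4 values shown sit.

From the compounds shown here alone, whether a hydroxyl or a carboxylic acid on this carbon would give a value short of that limit remains open. Going by these compounds, the true differences among compound 2, compound 3 and compound 4 also remain unknown.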